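Swapping Dichlorophenyl for Dimethoxyphenyl in a Growth Inhibitor

The compounds below may be only part of what the source reports. "The series", "measured", "known", "first", "only" and "open" are said of these compounds alone.

Of the compounds shown here, two sharing one core have been tested in a functional assay on UO-31 cells (Homo sapiens) for inhibition, read by sulforhodamine B assay, with a stated time of 48 h; on this read-out higher numbers stand for weaker inhibition of growth and lower numbers for stronger inhibition of growth. Compound 1 `CCOC(=O)[C@H](CCC(=O)O)NC(=O)c1ccc(CNc2nc3cc(N)cc(N)c3nc2-c2ccccc2)cc1` returns only a limit there, < 100000 nM. Compound 2 `Nc1cc(N)c2nc(-c3ccccc3)c(NCc3ccc(Cl)c(Cl)c3)nc2c1` likewise returns only a limit, < 100000 nM. Among the measured compounds shown here, both values thus sit at the same edge of the measurement, as the limit of < 100000 nM in this assay, at which 2 of the 2 values shown sit, records, so no step between measured compounds can be drawn. Compound 3 `COc1ccc(CNc2nc3cc(N)cc(N)c3nc2-c2ccccc2)cc1OC` carries 3,4-dimethoxyphenyl in place of 3,4-dichlorophenyl on a saturated chain carbon bound to a nitrogen on an aromatic ring. With only limits to lean on, the expected step is a step that the limit leaves unreadable from compound 2 to compound 3, nothing beyond the usual scatter. Compound 3 is therefore estimated at 30000 nM in this assay, expected to fall between 5000 nM and 100000 nM.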

Compound 3, concentration for total growth inhibition: 45700 nM
Compound 3: the middle estimate sits 1.5-fold (0.18 log units) below what was measured; low and high end bracket the measured number.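

Among the compounds shown here, no step from compound 2 to compound 3 can be read, because compound 2 gives only a limit: the limit of < 100000 nM in this assay, at which 2 of the 3 values shown sit.

The compounds shown leave open how large the effect of exchanging 3,4-dichlorophenyl for 3,4-dimethoxyphenyl is, and in which direction it runs.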